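Dimethylamino for methoxy on a benzylidene hydrazide

The source may report more compounds than this note shows. Statements on the series, on what has been measured and on what is new or still open speak of the compounds shown alone.

The study concerns three measured hydrazides, compound 1 `COc1ccc(/C=N/NC(=O)c2ccc(C)cc2O)cc1`, compound 2 `Cc1ccc(C(=O)N/N=C/c2ccc(Cl)cc2Cl)c(O)c1` and compound 3 `COc1cccc(/C=N/NC(=O)c2ccc(C)cc2O)c1`, and one unmeasured analogue, compound 4 `Cc1ccc(C(=O)N/N=C/c2ccc(N(C)C)cc2)c(O)c1`. In a functional assay (Mus musculus, strain BALB/C) for inhibition, read by MTT assay, with stated times of 24 h and 72 h (a higher number here means a weaker inhibitor, a lower number a stronger inhibitor), compound 1 gives only a limit, > 100000 nM, which is the limit of > 100000 nM in this assay, at which 1 of the 3 values shown sits. In this assay compound 2 gives 9780 nM, and compound 3 gives 20600 nM. Compound 1 therefore stands at the weak end of the numbers shown, with no exact value of its own.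

Compound 4 differs from compound 1 in one place: dimethylamino in place of methoxy on an aromatic carbon. Among the measured compounds shown here, no step between two measured compounds is available to guide this change, so the size of the step is open. For the change from methoxy to dimethylamino the estimated step is an at least 2.5-fold lower number from compound 1 to compound 4 (0.39 log units; beyond the scatter), an expected move toward a measurable half-maximal inhibitory concentration and toward stronger inhibition. Compound 4 is expected to give an estimated 40000 nM in this assay, within a range from 8000 nM to 200000 nM.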

Compound 4, half-maximal inhibitory concentration: > 100000 nM
Compound 4 was reported as a limit; the forecaster's own chance of this, stated with the estimate: 40%; middle value at least 2.5-fold (0.39 log units) from the limit.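

Compound 1 and compound 4 are both reported only as limits in this assay, so no step between them can be read: the limit of > 100000 nM in this assay, at which 2 of the 4 values shown sit.

The compounds shown leave open whether dimethylamino in place of methoxy changes inhibition at all.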